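The compounds below may be only part of what the source reports. "The series", "measured", "known", "first", "only" and "open" are said of these compounds alone.

Measured so far:
compound 1, `CC(C)[C@H](C[C@H]1OC(=O)NC1=O)c1ccc(-c2ccc3cccc(F)c3c2)[nH]c1=O`, 6 nM
compound 2, `C/C(=C1/OC(=O)NC1=O)C(c1ccc(-c2ccc3cccc(F)c3c2)[nH]c1=O)C(C)C`, 17 nM
compound 3, `O=C1NC(=O)/C(=C/C(c2ccc(-c3ccc4cccc(F)c4c3)[nH]c2=O)C2CCCC2)O1`, 9 nM

These three values come from an assay on membranes from Chem-1 cells for displacement of a labelled ligand from prostaglandin E2 receptor EP3 subtype (Homo sapiens), read by scintillation counting, with a stated time of 2 h; a lower number here means a stronger inhibitor, a higher number a weaker inhibitor. Compound 2 gives the highest of the three numbers. Its nearest neighbour is compound 3, whose number is lower by an amount that lies within the usual scatter, so the two cannot be told apart. Compound 1 lies further away, lower by an amount beyond the scatter, so compound 1 is the stronger inhibitor of that pair.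

The next compound, compound 4, has the structure `CC(C)C(CC1NC(=O)NC1=O)c1ccc(-c2ccc3cccc(F)c3c2)[nH]c1=O`. It differs from compound 2 in one place: a group of 8 heavy atoms (4 carbon, 2 nitrogen, 2 oxygen; one five-membered non-aromatic ring with 2 hetero atoms) in place of a group of 9 heavy atoms (5 carbon, 1 nitrogen, 3 oxygen; one five-membered non-aromatic ring with 2 hetero atoms), on a saturated chain carbon bound to an aromatic carbon and a saturated chain carbon. Both groups contain a five-membered non-aromatic ring with two hetero atoms, but the entering group carries two hydrogen-bond donors instead of one and two acceptors instead of three, and one fewer double bond outside aromatic rings.

Going by the values given here, no measured pair shows this particular change, so its size must be guessed from the spread of the three known values, which all sit within a narrow band. A modest move to a higher number is expected, of a size near the edge of the scatter, a 2.1-fold higher number from compound 2 to compound 4 (0.31 log units; beyond the scatter). Compound 4 is therefore estimated at 35 nM, with a likely range from 10 nM to 130 nM.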

Compound 4, inhibition constant: 10 nM
For compound 4 the middle estimate is 3.5-fold (0.54 log units) above the measured one; the range from low to high includes it.
By their numbers in this assay, from the lowest: compounds 1, 3, 4 and 2 (each within the scatter of the next, the first and the last beyond it).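

In this assay the exchange of the group in compound 2 for (2,5-dioxoimidazolidin-4-yl)methyl gives a 1.7-fold lower number from compound 2 to compound 4 (0.23 log units; within the scatter) and so leaves the two impossible to tell apart. Going by these compounds alone, the earlier compounds offered no pair differing in one place, so this is the only step that can be read at this position, on a saturated chain carbon bound to an aromatic carbon and a saturated chain carbon; it shows that the number stays within the scatter when the group goes from 1 hydrogen-bond donor and 3 acceptors to 2 donors and 2 acceptors, with one double bond fewer outside aromatic rings. Nothing shown here offers an explanation for this result.

A single step does not tell whether any one part of this exchange, the ring atoms, the donor count or the double bonds, matters on its own. Every group at this position so far holds a five-membered non-aromatic ring with 2 hetero atoms, so the compounds shown leave open what a carboxylic acid, an amine or a longer open chain would do there.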